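Swapping the Aryl Group on the Ring Amine

The source may hold more compounds than are shown below. What is called first, only, known or untested is meant among the compounds shown, and "the series" means these compounds.

Three compounds have been measured in an assay on CHO cells for displacement of a labelled ligand from adenosine receptor A3 (Homo sapiens), read by scintillation counting, with a stated time of 120 min, tested at 10 uM; on this read-out lower numbers stand for less inhibition and higher numbers for more inhibition at the one concentration tested (going by the name of the read-out):
compound 1 `Nc1scc(CN2CCN(c3ccc(Cl)cc3Cl)CC2)c1C(=O)c1ccc(Cl)cc1` gives 0%
compound 2 `Nc1scc(CN2CCN(c3cc(Cl)cc(Cl)c3)CC2)c1C(=O)c1ccc(Cl)cc1` gives 1%
compound 3 `Nc1scc(CN2CCN(c3ccc(F)cc3Cl)CC2)c1C(=O)c1ccc(Cl)cc1` gives 0%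

Compound 3 sits level with compound 1 at the digits shown, and the two together are the lowest of the three numbers; the remaining step among the three is a number 1 percentage points lower from compound 2 to compound 3 (within the scatter).

Compound 4 `COc1ccc(N2CCN(Cc3csc(N)c3C(=O)c3ccc(Cl)cc3)CC2)cc1` differs from compound 3 in one place: 4-methoxyphenyl in place of 2-chloro-4-fluorophenyl on an amine nitrogen in a ring. Two measured steps already exchange the group on this same ring nitrogen, a number 1 percentage points higher from compound 1 to compound 2 (within the scatter) and a number 1 percentage points lower from compound 2 to compound 3 (within the scatter), and both stay within the scatter. The step to compound 4 is therefore expected to stay within the scatter as well, a number 2 percentage points higher from compound 3 to compound 4 (within the scatter). For compound 4 the estimate in this assay is 2%, between 0% and 12%.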

Compound 4, a percentage reported as inhibition, at one concentration (the size of the read-out at that concentration, not a potency): 0%
Compound 4: the middle estimate sits 2 percentage points above what was measured, within the range that was stated.
By their numbers in this assay, from the lowest: compounds 1, 3, 4 and 2 (each within the scatter of the next).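

In this assay, for the compounds shown here, 4-methoxyphenyl is the first aryl group on this ring nitrogen without a halogen and with a hydrogen-bond acceptor, yet the steps are no change at the digits printed from compound 3 to compound 4 (within the scatter), no change at the digits printed from compound 1 to compound 4 (within the scatter) and a number 1 percentage points lower from compound 2 to compound 4 (within the scatter). Replacing the halogens with a methoxy group therefore leaves the number unmoved at the one concentration tested. Nothing available explains this result.

As far as these compounds go, it remains open whether a different group on this nitrogen, such as a benzyl group or a phenyl ring bearing a carboxylic acid, would move inhibition beyond the scatter. Changes elsewhere on the shared core also remain open.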